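Three Cytotoxicity Readings and One Bromo-to-Chloro Swap

A few compounds are considered here, and "the series" means these few. Any claim that something is new, unique, unknown or untested is made for them only; others in the source may bear on it.

Measured compounds:
Compound 1, `Cc1cc(O)c(C(=O)/C=C/c2cccc(Cl)c2)c(-c2ccccc2)c1C(=O)/C=C/c1cccc(Cl)c1`, gives 15000 nM in an ADME assay on HEK293 cells (Homo sapiens) for cytotoxicity, read by MTT assay, with a stated time of 24 h; a lower number here means a stronger inhibitor, a higher number a weaker inhibitor.
Compound 2, `Cc1cc(O)c(C(=O)/C=C/c2ccc(Cl)cc2)c(-c2ccc(Br)cc2)c1C(=O)/C=C/c1ccc(Cl)cc1`, gives 25000 nM in this assay.
Compound 3, `Cc1cc(O)c(C(=O)/C=C/c2ccc(F)cc2)c(-c2ccc(OCc3ccccc3)cc2)c1C(=O)/C=C/c1ccc(F)cc1`, gives 30000 nM in this assay.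

Among these three numbers compound 2 stands second highest. Its nearest neighbour is compound 3, whose number is within the scatter of that of compound 2, and its furthest is compound 1, whose number is also within the scatter. On the numbers shown, then, the three measured compounds cannot be told apart in this assay; no one of them can be called the weaker or the stronger.

Compound 4, `Cc1cc(O)c(C(=O)/C=C/c2ccc(Cl)cc2)c(-c2ccc(Cl)cc2)c1C(=O)/C=C/c1ccc(Cl)cc1`, has not yet been measured. It differs from compound 2 in one place: chloro in place of bromo on an aromatic carbon, para to a large group. Within the data shown here, no pair of measured compounds differing in a single place is available, so the size of such a step in this assay is not known from the data. Given that all three measured numbers sit within the scatter of one another, the expectation is a step of no size beyond the scatter, in neither direction, for the change from compound 2 to compound 4, a 1.1-fold lower number from compound 2 to compound 4 (0.06 log units; within the scatter). Compound 4 is therefore estimated at 22000 nM, within a range from 10000 nM to 45000 nM.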

Compound 4, half-maximal inhibitory concentration: "not active" (no number reported)
No number was reported for compound 4; there is nothing to compare the estimate with.
By their numbers in this assay, from the lowest: compounds 1, 2 and 3 (each within the scatter of the next).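

In this assay, among these compounds, compound 4 is reported as "not active" without a number, and no step from compound 2 to compound 4 can be read. Nothing shown bears on this result. The compounds shown leave open how far a change in a single place moves the number in this assay.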